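The compounds below may be only part of what the source reports. "The series", "measured", "known", "first", "only" and "open" are said of these compounds alone.

Measured in an ADME assay for pharmacokinetics; a higher number here means that the compound lasts longer, a lower number that the compound disappears faster:

- Compound 1 `CC(=O)Nc1nc2nc(C)ncc2cc1-c1c(Cl)cccc1Cl`: < 0.0834 h, a limit of the assay rather than a number
- Compound 2 `Cc1ncc2cc(-c3c(Cl)cccc3Cl)c(NC(=O)c3ccco3)nc2n1`: 4 h
- Compound 3 `COC(=O)Nc1nc2nc(C)ncc2cc1-c1c(Cl)cccc1Cl`: 6 h

Compound 3 cannot be told apart from compound 2, since the measured step shows a 1.5-fold higher number from compound 2 to compound 3 (0.18 log units; within the scatter). Both stand far from compound 1, with an at least 47-fold higher number from compound 1 to compound 2 (1.68 log units; beyond the scatter) and an at least 71-fold higher number from compound 1 to compound 3 (1.85 log units; beyond the scatter).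

Compound 4 `CC(=O)N(C)c1nc2nc(C)ncc2cc1-c1c(Cl)cccc1Cl` is made from compound 3 by putting acetyl(methyl)amino in place of (methoxycarbonyl)amino on an aromatic carbon. The new group brings back the methyl on a carbonyl carbon found in compound 1, so the two large steps away from compound 1 bear most directly on this change. Read in reverse, they point to a large fall in this assay. However, compound 4 also carries a second methyl in its acetyl(methyl)amino group, which compound 1 lacks, and no measured compound shows what that methyl does. A fall is therefore expected, though probably a smaller one than those steps alone would suggest, and the uncertainty is wide.

The estimated change is a 7.5-fold lower number from compound 3 to compound 4 (0.88 log units; beyond the scatter).

The half-life expected for compound 4 is 0.8 h, with an estimated range of 0.1 h to 5 h.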

Compound 4, half-life in the ADME assay: 1.6 h
The estimate for compound 4 lay 2.0-fold (0.30 log units) below the measured number; measured number inside the range.
By their numbers in the ADME assay, from the lowest: compound 4; then compounds 2 and 3 (each within the scatter of the next). At a limit, below all of these: compound 1.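

Methyl in place of hydrogen on the amide-type nitrogen of compound 1 is the one step here that changes only that nitrogen, and in the ADME assay it gives an at least 19-fold higher number from compound 1 to compound 4 (1.28 log units; beyond the scatter), so a nitrogen without the amide hydrogen can still carry a measurable half-life. In the ADME assay compound 1 gives < 0.0834 h as a limit of the assay and not a number, so the size of that step is only a bound: the limit of < 0.0834 h in the ADME assay, at which 1 of the 4 values shown sits.

Even so, acetyl(methyl)amino does not match the two other groups at this position in the ADME assay, with a 3.8-fold lower number from compound 3 to compound 4 (0.57 log units; beyond the scatter) and a 2.5-fold lower number from compound 2 to compound 4 (0.40 log units; beyond the scatter), so compound 4 sits clearly apart from the pair that could not be told apart before. In a physicochemical assay for acid dissociation, compound 3 gives 4.2 and compound 4 gives 4.2 and the same exchange gives no change at the digits printed from compound 3 to compound 4 (within the scatter), so that read-out does not follow the shift in half-life between these two compounds.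

Still open, from the compounds shown here alone, is whether a methyl on the nitrogen would do the same to the (methoxycarbonyl)amino group of compound 3 or the furan-2-yl amide of compound 2, which would separate the effect of that methyl from the effect of the group on the carbonyl carbon. Also open, going by these compounds, is how an ethyl on that nitrogen, or an amine on the carbonyl carbon, would behave on the shared core.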